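The source may hold more compounds than are shown below. What is called first, only, known or untested is meant among the compounds shown, and "the series" means these compounds.

Of the compounds shown here, three have so far been tested in a functional assay on the whole organism (Hindlimb, strain albino) with Mus musculus as the target, in the maximal electroshock model, with a stated time of 0.5 h; on this read-out lower numbers stand for an effect already at smaller amounts and higher numbers for an effect only at larger amounts of compound. Compound 1 `COc1ccc(/C=C/C(=O)Nc2nc3ccc(Cl)cc3s2)cc1O` gives 320 umol/kg. For the measured compounds named here, compound 2 `O=C(/C=C/c1ccccc1)Nc1nc2ccc(Cl)cc2s1` gives 425 umol/kg, a number that sits within the usual scatter of the one for compound 1, so the two cannot be told apart on these data. Compound 3 `CC(=O)N1N=C(Nc2nc3ccc(Cl)cc3s2)CC1c1ccc(O)cc1` gives 106 umol/kg, a lower number than compound 1 shows, and that gap lies beyond the scatter. Compound 1 thus stands, together with compound 2, at the higher end of the numbers seen so far.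

The next compound, compound 4 `COc1ccc(/C=C/C(=O)Nc2nc3ccc(C)cc3s2)cc1O`, is compared with compound 1. The change is methyl in place of chloro on an aromatic carbon. Going by the values given here, no pair of measured compounds differs in just this one place, so the size of the step has no direct precedent here. A swap of one small group for another at the same spot, with nothing else altered, often leaves a dose read-out close to where it was, and the expected step is one that stays within the scatter, perhaps tilting toward a higher number: a 1.2-fold higher number from compound 1 to compound 4 (0.07 log units; within the scatter). For compound 4 the estimated dose in this assay is 380 umol/kg, with a range from 170 umol/kg to 850 umol/kg.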

Compound 4, dose for half-maximal effect: 271 umol/kg
Estimate against measurement, compound 4: 1.4-fold (0.15 log units) above; the measured number falls inside the stated range.
By their numbers in this assay, from the lowest: compound 3; then compounds 4, 1 and 2 (each within the scatter of the next).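

In this assay, putting methyl in place of chloro gives a 1.2-fold lower number from compound 1 to compound 4 (0.07 log units; within the scatter), so at this spot on the six-membered aromatic ring the two groups cannot be told apart. For the compounds shown here, this is the first pair that differs in just one place, and it shows that the chloro group can be exchanged for methyl here without a step beyond the scatter. No measurement here bears on why the two groups read alike.

Going by these compounds, whether a quite different group at this spot, such as an amine or a carboxylic acid, would move the number beyond the scatter remains open. On these data alone, it is also open whether the same swap would give a similarly small step on the core of compound 2 or compound 3.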